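The compounds below may be only part of what the source reports. "The series", "measured", "known", "first", "only" and "open" are said of these compounds alone.

Three compounds built on one shared core were tested in an assay on isolated protein for inhibition of protein deacetylase HDAC6 (Homo sapiens), read by fluorescence, with a stated time of 15 min; on this read-out lower numbers stand for stronger inhibition and higher numbers for weaker inhibition. Compound 1 `O=C(NO)c1ccc(/C=C/c2ccnc(-c3cccc(O)c3)c2)cc1` gives 19 nM, compound 2 `O=C(NO)c1ccc(/C=C/c2ccnc(-c3cccc(CO)c3)c2)cc1` gives 34 nM, and compound 3 `O=C(NO)c1ccc(/C=C/c2ccncc2)cc1` gives 130 nM, the highest number of the three. Compound 4 `O=C(NO)c1ccc(/C=C/c2ccnc(-c3ccsc3)c2)cc1` differs from compound 3 by thiophen-3-yl in place of hydrogen on an aromatic carbon. Among the measured compounds shown here, two measured steps bear on this change: a 6.8-fold higher number from compound 1 to compound 3 (0.84 log units; beyond the scatter) and a 3.8-fold higher number from compound 2 to compound 3 (0.58 log units; beyond the scatter), each taking a substituted phenyl off the same aromatic carbon where the thiophen-3-yl of compound 4 would sit. Putting a ring back there is therefore expected to lower the number, though the thiophen-3-yl carries no hydroxy or hydroxymethyl, so a step of modest size is expected, a 3.3-fold lower number from compound 3 to compound 4 (0.51 log units; beyond the scatter). Compound 4 is estimated at 40 nM, with a likely range from 15 nM to 110 nM.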

Compound 4, half-maximal inhibitory concentration: 54 nM
Compound 4: the middle estimate sits 1.4-fold (0.13 log units) below what was measured, within the range that was stated.
By their numbers in this assay, from the lowest: compounds 1, 2 and 4 (each within the scatter of the next, the first and the last beyond it); then compound 3.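

A ring carrying no hydroxy or hydroxymethyl still counts at this place next to the ring nitrogen: adding thiophen-3-yl gives a 2.4-fold lower number from compound 3 to compound 4 (0.38 log units; beyond the scatter). Swapping the substituted phenyls for thiophen-3-yl gives a 1.6-fold higher number from compound 2 to compound 4 (0.20 log units; within the scatter) and a 2.8-fold higher number from compound 1 to compound 4 (0.45 log units; beyond the scatter), so only the 3-hydroxyphenyl keeps a real edge over it. Nothing available explains these differences.

Open, on these data alone, is whether an unsubstituted phenyl would match thiophen-3-yl, which would separate the effect of the ring from that of its hydroxy. Also open, as far as these compounds go, is how an amine or a carboxylic acid on that ring would compare.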